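This account rests on a few compounds, and the source may have more. Where it says the series, first, only, none or still open, it means among the compounds named here.

Compound 1 `CC1CC/C(=N\Nc2ccc(Cl)cc2)c2ncc(C(=O)O)c(=O)n21` was tested in a functional assay on the whole organism for inhibition, with Rattus norvegicus as the target (on this read-out lower numbers stand for an effect already at smaller amounts and higher numbers for an effect only at larger amounts of compound), and compound 1 gives 0.5 umol/kg. Going by the values given here, that is the lowest of the two numbers measured so far. Among the compounds with values here, the only comparison is compound 2 `CCOc1ccc(N/N=C2\CC[C@H](C)n3c2ncc(C(=O)O)c3=O)cc1`, which in this assay gives 100 umol/kg for compound 2, a much higher number than compound 1, well beyond the scatter of repeated measurements. Nothing else is known about how changes around this core move the read-out.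

Compound 3 `Cc1ccc(N/N=C2\CCC(C)n3c2ncc(C(=O)O)c3=O)cc1` has not yet been measured. It differs from compound 1 in one place: methyl in place of chloro on an aromatic carbon. The exchanged group sits on an aromatic carbon of a six-membered aromatic ring of carbon only, para to a large group. Since only the two values of compound 1 and compound 2 are available, the size of this step can only be estimated, and a modest shift toward a somewhat higher number, a little beyond the scatter, is expected as a 4.0-fold higher number from compound 1 to compound 3 (0.60 log units; beyond the scatter). Compound 3 is therefore expected to give about 2 umol/kg, with a likely range from 0.5 umol/kg to 10 umol/kg.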

Compound 3, dose for 50% inhibition: 1.3 umol/kg
Compound 3: middle estimate off by 1.5-fold (0.19 log units), on the high side; low and high end bracket the measured number.
By their numbers in this assay, from the lowest: compound 1; then compound 3; then compound 2.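

Methyl in place of chloro on an aromatic carbon, para to a large group, gives a 2.6-fold higher number from compound 1 to compound 3 (0.41 log units; beyond the scatter) in this assay and so provides the first reading of what a single exchange does at this position. The step is modest but beyond the scatter, which means that this place on the ring does register the swap of one small group for another, even though the number of heavy atoms stays the same and neither group carries a hydrogen-bond donor, a hydrogen-bond acceptor or a net charge. Compound 3 still gives 1.3 umol/kg and stays close to the chloro compound, so chloro is not required for an effect at small doses, while nothing available here explains the difference between the two groups.

Going by these compounds, how a fluoro, a bromo or a trifluoromethyl group, or an amine, would read at this same place remains open, and two groups alone cannot define a trend. Also open, on these data alone, is whether a step of this size would recur on another carbon of the ring, or whether it would hold with an amide in place of the carboxylic acid on the shared core.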